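This account rests on a few compounds, and the source may have more. Where it says the series, first, only, none or still open, it means among the compounds named here.

The measured compounds are compound 1 `CCOC(=O)/C=C/c1ccncc1-c1ccc2[nH]ccc2c1`, compound 2 `CCOC(=O)/C=C/c1ccncc1-c1ccc2c(ccn2C)c1` and compound 3 `COC1CN(C(=O)/C=C/c2ccncc2-c2ccc3ccccc3c2)C1`.

In a functional assay on MDA-MB-231 cells (Homo sapiens) for inhibition, read by sulforhodamine B assay, with a stated time of 72 h (on this read-out higher numbers stand for weaker inhibition of growth and lower numbers for stronger inhibition of growth), compound 2 gives 10200 nM. For compound 1 the this assay reports only a limit, > 10000 nM. For compound 3 it likewise reports only a limit, > 10000 nM. Compound 2 thus stands as the only number shown; the other two values sit at the limit of > 10000 nM in this assay, at which 2 of the 3 values shown sit. Among the compounds with values here, the one measured step, a step that the limit leaves unreadable from compound 1 to compound 2, has a size the limit leaves unreadable. Compound 4 `Cn1ccc2cc(-c3cnccc3/C=C/C(=O)O)ccc21` differs from compound 2 by hydrogen in place of ethyl on an oxygen next to a carbonyl group. Within the data shown here, no measured step touches the ethoxycarbonyl group, so nothing measured bears on this change, and no step beyond the scatter is expected in this assay. Compound 4 is estimated at 15000 nM, between 5000 nM and 50000 nM. That estimate means an expected step of a 1.5-fold higher number from compound 2 to compound 4 (0.17 log units; within the scatter).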

Compound 4, concentration for 50% growth inhibition: > 10000 nM
Compound 4 gave a limit, no number; the forecaster's own chance of this, stated with the estimate: 60%; the middle value does not contradict the limit.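

In this assay compound 4 gives only a limit, > 10000 nM, so the step from compound 2 to compound 4 cannot be read. The compounds shown leave open whether hydrogen in place of ethyl on an oxygen next to a carbonyl group alters growth inhibition.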